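The source may report more compounds than this note shows. Statements on the series, on what has been measured and on what is new or still open speak of the compounds shown alone.

Compound 1 `Cc1ccc2nc(Nc3nc(Nc4ccc(S(N)(=O)=O)cc4)ncc3F)sc2c1` in a functional assay on MCF7 cells (Homo sapiens) for antiproliferative activity, read by MTT assay, with a stated time of 48 h; a higher number here means a weaker inhibitor, a lower number a stronger inhibitor: 24500 nM
Compound 2 `Cc1ccc2nc(Nc3nc(Nc4ccc(S(N)(=O)=O)cc4)ncc3C)sc2c1`: a limit, > 50000 nM
Compound 3 `Cc1ccc2nc(Nc3ccnc(Nc4ccc(S(N)(=O)=O)cc4)n3)sc2c1`: 5740 nM

Compound 2 stands at the weak end of the three: its value in this assay is a limit of the assay and not a number (the limit of > 50000 nM in this assay, at which 1 of the 3 values shown sits), so no number is known for it. Compound 1 is a measured value, and compound 3 is a measured value some way lower than it; a 4.3-fold lower number from compound 1 to compound 3 (0.63 log units; beyond the scatter), an at least 2.0-fold higher number from compound 1 to compound 2 (0.30 log units; that floor lies within the scatter), an at least 8.7-fold lower number from compound 2 to compound 3 (0.94 log units; beyond the scatter).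

Compound 4 `Cc1cnc(Nc2ccc(S(N)(=O)=O)cc2)nc1Nc1nc2ccc(F)cc2s1` is reached from compound 2 by fluoro in place of methyl on an aromatic carbon. Going by the values given here, none of the measured steps sits at this place on the shared core; all three exchange the group on a different ring. Among the compounds with values here, the only step exchanging the same two groups, an at least 2.0-fold higher number from compound 1 to compound 2 (0.30 log units; that floor lies within the scatter), runs in the opposite direction and sets a floor that lies within the scatter. Compound 4 is therefore expected to give 35000 nM in this assay, within 10000 nM to 100000 nM, a step of an at least 1.4-fold lower number from compound 2 to compound 4 (0.15 log units; that floor lies within the scatter) that may again end at the limit.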

Compound 4, half-maximal inhibitory concentration: > 50000 nM
Compound 4 was reported as a limit (the forecaster's own chance of this, stated with the estimate: 45%); middle value at least 1.4-fold (0.15 log units) from the limit.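

Compound 2 and compound 4 both stand at a limit of this assay and not at a number, so no step between them can be read: the limit of > 50000 nM in this assay, at which 2 of the 4 values shown sit.

The compounds shown leave open whether fluoro in place of methyl on this aromatic carbon changes the activity at all, and in which direction.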